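The source may report more compounds than this note shows. Statements on the series, on what has been measured and on what is new or still open speak of the compounds shown alone.

Measured so far:
compound 1 `COc1ccc2[nH]c(C)c(Br)c(=O)c2c1` — 1.62
compound 2 `Cc1[nH]c2ccc(Cl)cc2c(=O)c1Br` — 2.02
compound 3 `COc1ccc2c(=O)c(Cc3ccccc3)c(C)[nH]c2c1` — 2.52

All three were measured in a physicochemical assay for lipophilicity, at pH 7.4; on this read-out higher numbers stand for higher lipophilicity and lower numbers for lower lipophilicity. Compound 1 and compound 2 differ in one place: chloro in place of methoxy on an aromatic carbon. This change made a step of a number 0.40 log units higher from compound 1 to compound 2 (beyond the scatter). Compound 3 stands highest of the three numbers in this assay; the nearest to it is compound 2, which sits lower, and the furthest is compound 1, which sits lower still. How the core of compound 3 differs from the core of compound 1 is not broken down here.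

Compound 4 `Cc1[nH]c2cc(Cl)ccc2c(=O)c1Cc1ccccc1` has not yet been measured in this assay. It differs from compound 3 in one place: chloro in place of methoxy on an aromatic carbon. This is the same change as that from compound 1 to compound 2, made in the same place, and among the compounds shown it occurs twice in all. Because the earlier step was a number 0.40 log units higher from compound 1 to compound 2 (beyond the scatter), a step of similar size is expected here, namely an estimated a number 0.40 log units higher from compound 3 to compound 4 (beyond the scatter). On that basis compound 4 is expected to give about 2.92 in this assay, most likely between 2.6 and 3.25.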

Compound 4, distribution coefficient: 2.69
For compound 4 the middle estimate is 0.23 log units above the measured one, within the range that was stated.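

In this assay, chloro in place of methoxy gives a number 0.17 log units higher from compound 3 to compound 4 (within the scatter), while the same change on the core of compound 1 gives a number 0.40 log units higher from compound 1 to compound 2 (beyond the scatter). The change therefore cannot be relied on to add a clear, fixed step on every core: it stands clear of the usual scatter on the core of compound 1 but not on the core of compound 3. Two examples cannot show whether the two cores truly respond differently, and no measurement here offers an explanation for the two results.

As far as these compounds go, it remains open whether the same change would give a clear step on any further core, or whether the result on the core of compound 3 is the more typical one. Also open, from the compounds shown here alone, is how an amine, a carboxylic acid or a longer chain on that aromatic carbon would read in this assay on either core.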